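The source may report more compounds than this note shows. Statements on the series, on what has been measured and on what is new or still open speak of the compounds shown alone.

Measured in a functional assay on SW-620 cells (Homo sapiens) for cytotoxicity, read by MTT assay, with stated times of 4 h and 72 h, tested at 5 uM; on this read-out higher numbers stand for weaker inhibition and lower numbers for stronger inhibition:
- compound 1 `Cc1cc(Nc2ccc(C(=O)/C=C/c3ccc4ccccc4c3)cc2)n2nc(SCc3cccc(Br)c3)nc2n1`: 270 nM
- compound 2 `Cc1cc(Nc2ccc(C(=O)/C=C/c3ccc4ccccc4c3)cc2)n2nc(SCc3ccc(Cl)cc3)nc2n1`: 570 nM
- compound 3 `Cc1cc(Nc2ccc(C(=O)/C=C/c3ccc4ccccc4c3)cc2)n2nc(SCc3ccc(F)cc3)nc2n1`: 320 nM

Compound 3, at 320 nM, sits within the scatter of both other compounds: a 1.2-fold higher number from compound 1 to compound 3 (0.07 log units; within the scatter), and a 1.8-fold lower number from compound 2 to compound 3 (0.25 log units; within the scatter). Compound 4 `Cc1cc(Nc2ccc(C(=O)/C=C/c3ccc4ccccc4c3)cc2)n2nc(SCc3ccccc3[N+](=O)[O-])nc2n1` keeps the shared core and changes one group: 2-nitrophenyl in place of 4-fluorophenyl on a saturated chain carbon bound to a sulfur. In words, 2-nitrophenyl stands in place of 4-fluorophenyl on a saturated chain carbon bound to a sulfur. Earlier swaps at this place moved the number little, the largest being modest: a 2.1-fold higher number from compound 1 to compound 2 (0.32 log units; beyond the scatter). Among the measured compounds shown here, no measured compound carries a nitro group, so this guide is loose. No step beyond the scatter is expected in this assay, and the expected move is a 1.3-fold higher number from compound 3 to compound 4 (0.10 log units; within the scatter). The estimate for compound 4 is 400 nM, with an expected range of 150 nM to 1100 nM.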

Compound 4, half-maximal inhibitory concentration: 960 nM
For compound 4 the middle estimate is 2.4-fold (0.38 log units) below the measured one, and the stated range covers the measured number.
By their numbers in this assay, from the lowest: compounds 1, 3, 2 and 4 (each within the scatter of the next, the first and the last beyond it).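

In this assay, among the compounds shown here, 2-nitrophenyl is the first group at this place to stand beyond the scatter from two other compounds: a 3.0-fold higher number from compound 3 to compound 4 (0.48 log units; beyond the scatter) and a 3.6-fold higher number from compound 1 to compound 4 (0.55 log units; beyond the scatter). Against the 4-chlorophenyl compound the gap is smaller, with a 1.7-fold higher number from compound 2 to compound 4 (0.23 log units; within the scatter), so the number at this place depends on what the phenyl ring carries, though all these steps remain modest. Nothing shown here explains the rise. On these data alone, it remains open whether the nitro group itself or its place on the ring sets the number. A 4-nitrophenyl or 2-aminophenyl group here would help separate the two.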